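The source may report more compounds than this note shows. Statements on the series, on what has been measured and on what is new or still open speak of the compounds shown alone.

Measured compounds and their values:

- Compound 1, `O=C(Nn1c(-c2cccc([N+](=O)[O-])c2)nc2c(-c3ccco3)n[nH]c2c1=O)c1cccnc1`, gives 11.7%
- Compound 2, `COc1cccc(-c2nc3c(-c4ccco4)n[nH]c3c(=O)n2NC(=O)c2cccnc2)c1`, gives 12.8%
- Compound 3, `CCCc1n[nH]c2c(=O)n(NC(=O)c3ccccc3)c(-c3cccc([N+](=O)[O-])c3)nc12`, gives 18.7%

All three were tested in a functional assay on HT-29 cells (Homo sapiens) for cytotoxicity, read by sulforhodamine B assay, with a stated time of 2 days, tested at 100 uM; a higher number here means more inhibition at the concentration tested (going by the name of the read-out), a lower number less inhibition. Compound 1 and compound 2 share a core and differ in one group only: methoxy in place of nitro on an aromatic carbon. That change made the step of a number 1.1 percentage points higher from compound 1 to compound 2 (within the scatter), a step that stays within the usual scatter of this assay. Compound 3 carries a different core; how the core of compound 3 differs from the core of compound 1 is not broken down here, and the two values of compound 1 and compound 3 sit within the scatter of each other.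

Compound 4, `CCCc1n[nH]c2c(=O)n(NC(=O)c3ccccc3)c(-c3cccc(OC)c3)nc12`, has not yet been measured. It relates to compound 3 exactly as compound 2 relates to compound 1: methoxy in place of nitro on an aromatic carbon. Within the data shown here, since the only measured example of this change gave a number 1.1 percentage points higher from compound 1 to compound 2 (within the scatter), the expected step on the core of compound 3 is a number 0.3 percentage points higher from compound 3 to compound 4 (within the scatter), again within the scatter. On that basis the value of compound 4 in this assay is estimated at 19%, with a likely range from 8% to 30%.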

Compound 4, a percentage reported as inhibition, at one concentration (the size of the read-out at that concentration, not a potency): 6.27%
Compound 4: middle estimate off by 12.7 percentage points, on the high side; measured number below the stated range.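

In this assay, replacing nitro with methoxy, which turns 3-nitrophenyl into 3-methoxyphenyl, gave a number 12.4 percentage points lower from compound 3 to compound 4 (beyond the scatter) on this second core. This result does not show that the core alters the effect of the change, since the two steps cannot be told apart, but it does not show that the change carries over unaltered either, and two pairs are a thin basis for any rule. Set side by side, the steps compare as follows: the same change on two cores in this assay, a number 1.1 percentage points higher (within the scatter) from compound 1 to compound 2 and a number 12.4 percentage points lower (beyond the scatter) from compound 3 to compound 4, 13.5 percentage points apart, within the scatter of two such steps

The compounds shown leave open how other groups at this same place on the aromatic ring, such as an amine or a carboxylic acid, would compare with nitro and methoxy. They also leave open whether a longer chain on the core of compound 3 would move the number, and only a matched pair differing in that one place could answer this.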